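The compounds below may be only part of what the source reports. "The series", "measured", "known", "first", "only" and "open" are said of these compounds alone.

Measured in an assay on HEK293 cells for displacement of a labelled ligand from 5-hydroxytryptamine receptor 7 (Homo sapiens); a higher number here means a weaker inhibitor, a lower number a stronger inhibitor:
compound 1 `O=C1c2ccccc2S(=O)(=O)N1CCCCCN1CCN(c2ccc(Cl)cc2)CC1` gives 191 nM
compound 2 `O=C1c2ccccc2S(=O)(=O)N1CCCCCN1CCN(c2ccccc2)CC1` gives 148 nM
compound 3 `COc1ccccc1N1CCN(CCCCCN2C(=O)c3ccccc3S2(=O)=O)CC1` gives 125 nM

Compound 3 holds the lowest of the three numbers, but its gaps to the others stay within the scatter: a 1.5-fold lower number from compound 1 to compound 3 (0.18 log units; within the scatter) and a 1.2-fold lower number from compound 2 to compound 3 (0.07 log units; within the scatter). Compound 4 `O=C1c2ccccc2S(=O)(=O)N1CCCCCN1CCN(c2ccccn2)CC1` differs from compound 3 by pyridin-2-yl in place of 2-methoxyphenyl on an amine nitrogen in a ring. Going by the values given here, no measured step swaps the aryl ring itself for a heteroaryl; the steps that bear on it are the variations of the group on the ring nitrogen, a 1.3-fold lower number from compound 1 to compound 2 (0.11 log units; within the scatter), a 1.5-fold lower number from compound 1 to compound 3 (0.18 log units; within the scatter) and a 1.2-fold lower number from compound 2 to compound 3 (0.07 log units; within the scatter), none of which moved this assay beyond the scatter. A small step is therefore expected from compound 3 to compound 4, a 1.4-fold higher number from compound 3 to compound 4 (0.13 log units; within the scatter), with no direction beyond the scatter. For compound 4 the expected value in this assay is 170 nM, range 80 nM to 400 nM.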

Compound 4, inhibition constant: 179 nM
For compound 4 the middle estimate is 1.1-fold (0.02 log units) below the measured one, and the stated range covers the measured number.
By their numbers in this assay, from the lowest: compounds 3, 2, 4 and 1 (each within the scatter of the next).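

Placing pyridin-2-yl on the amine nitrogen brings a ring with a hetero atom to this position, and every comparison with the carbon-only aryl groups stays small: a 1.4-fold higher number from compound 3 to compound 4 (0.16 log units; within the scatter), a 1.2-fold higher number from compound 2 to compound 4 (0.08 log units; within the scatter) and a 1.1-fold lower number from compound 1 to compound 4 (0.03 log units; within the scatter). In this assay, the hetero atom in this ring therefore gives no readable separation from the 2-methoxyphenyl, phenyl or 4-chlorophenyl compounds. No measured evidence bears on this result.

Open, on these data alone, is whether a pyrimidin-2-yl or benzyl group on the same ring nitrogen would move this assay beyond the scatter. As far as these compounds go, a longer chain also remains open.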